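The compounds below may be only part of what the source reports. "The series", "measured", "known", "first", "only" and "open" are said of these compounds alone.

Compound 1 `Cc1nnc(SCC(=O)c2ccc(Cl)cc2)n1N1C(=O)c2ccccc2C1=O` — in a functional assay on A549 cells (Homo sapiens) for cytotoxicity, read by MTT assay, with a stated time of 48 h (a lower number here means a stronger inhibitor, a higher number a weaker inhibitor), compound 1 gives > 200000 nM, a limit of the assay.
Compound 2 `C#CCSc1nnc(C)n1N1C(=O)c2ccccc2C1=O` — compound 2 gives > 200000 nM, again a limit.
Compound 3 `C#CCSc1nnc(CC)n1N1C(=O)c2ccccc2C1=O` — compound 3 gives > 200000 nM, also a limit.

Compound 3 therefore stands only at a limit, where all three measured values sit (the limit of > 200000 nM in this assay, at which 3 of the 3 values shown sit). Compound 4 `CCOC(=O)CSc1nnc(CC)n1N1C(=O)c2ccccc2C1=O` differs from compound 3 by ethoxycarbonyl in place of ethynyl on a saturated chain carbon bound to a sulfur. Among the compounds with values here, two measured steps touch this change: a step that the two limits leave unreadable from compound 1 to compound 2, another swap on the saturated chain carbon bound to a sulfur, and a step that the two limits leave unreadable from compound 2 to compound 3; neither has a readable size, because both ends rest at the limit (the limit of > 200000 nM in this assay, at which 3 of the 3 values shown sit). No step size can therefore be read for compound 4, and the expectation is that compound 4 also comes out at the limit, an expected step that the limit leaves unreadable from compound 3 to compound 4. Compound 4 is thus estimated at 300000 nM, within 100000 nM to 1000000 nM.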

Compound 4, half-maximal inhibitory concentration: > 200000 nM
Compound 4: no number, only a limit (the forecaster's own chance of this, stated with the estimate: 85%); the middle value is on the limit's open side.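

No step can be read from compound 3 to compound 4, since both rest at a limit: the limit of > 200000 nM in this assay, at which 4 of the 4 values shown sit.

The compounds shown leave open what true value any of the four has, and whether swapping the group on the saturated chain carbon bound to a sulfur changes it at all.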